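The source may report more compounds than this note shows. Statements on the series, on what has been measured and on what is new or still open speak of the compounds shown alone.

Of the compounds shown here, three built on one shared core have so far been tested in a functional assay on SK-BR-3 cells (Homo sapiens) for antiproliferative activity; on this read-out lower numbers stand for stronger inhibition and higher numbers for weaker inhibition. Compound 1 `CC(C)=CCc1cc(C(=O)Nc2cc3ccc(OCC4CCN(C)C4)c(C)c3oc2=O)ccc1O` gives 920 nM. Compound 2 `CC(C)=CCc1cc(C(=O)Nc2cc3ccc(OCCCN4CCCC4)c(C)c3oc2=O)ccc1O` gives 720 nM, and compound 3 `CCNCCCOc1ccc2cc(NC(=O)c3ccc(O)c(CC=C(C)C)c3)c(=O)oc2c1C` gives 720 nM. Compound 2 stands level with compound 3 at the digits shown, the two together at the lowest numbers of the three, with compound 1 the furthest away; the step of a 1.3-fold lower number from compound 1 to compound 2 (0.11 log units; within the scatter), the step of a 1.3-fold lower number from compound 1 to compound 3 (0.11 log units; within the scatter) and the step of no change at the digits printed from compound 2 to compound 3 (within the scatter) all lie within the scatter. Across these three compounds, then, changing the group on a saturated chain carbon, three bonds along the chain from an oxygen on an aromatic ring, has not moved the read-out in a way that can be trusted.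

Compound 4 `CC(C)=CCc1cc(C(=O)Nc2cc3ccc(OCCCNc4ccccc4)c(C)c3oc2=O)ccc1O` has not yet been measured. It differs from compound 2 in one place: anilino in place of pyrrolidin-1-yl on a saturated chain carbon, three bonds along the chain from an oxygen on an aromatic ring. The measured step that bears most directly on this is no change at the digits printed from compound 2 to compound 3 (within the scatter), where another group replaced the same pyrrolidin-1-yl at the same place without moving the number. Among the compounds with values here, that comparison is only partial, since an anilino group brings an aromatic ring that none of the measured compounds carries at this place. Within the data shown here, no measured step points to a direction, and the expected step is a 1.4-fold higher number from compound 2 to compound 4 (0.14 log units; within the scatter). Compound 4 is therefore estimated at 1000 nM, with a range from 400 nM to 2500 nM.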

Compound 4, half-maximal inhibitory concentration: > 50000 nM
Compound 4 ended at the assay's limit; the forecaster's own chance of this, stated with the estimate: 5%; middle value at least 50-fold (1.69 log units) away from the limit.
By their numbers in this assay, from the lowest: compounds 2, 3 and 1 (each within the scatter of the next). At a limit, above all of these: compound 4.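

Compound 4 stands at a limit of the read-out and not at a number: the limit of > 50000 nM in this assay, at which 1 of the 4 values shown sits. The earlier compounds shown here made this place on the chain look indifferent, yet it is not, as the change to anilino gives an at least 69-fold higher number from compound 2 to compound 4 (1.84 log units; beyond the scatter), and the same jump appears in an at least 69-fold higher number from compound 3 to compound 4 (1.84 log units; beyond the scatter) and in an at least 54-fold higher number from compound 1 to compound 4 (1.73 log units; beyond the scatter). The step from compound 3 is the plainest of the three, since the chain and its amine nitrogen stay and only ethyl gives way to phenyl, so the groups at this place are not interchangeable, and a single change on that nitrogen is enough to separate compound 4 from the rest.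

With only one aromatic group at this place, the compounds shown cannot tell whether the aromatic ring as such goes with the large step or whether any six-membered ring on the amine nitrogen would do the same. A cyclohexylamino group on the same chain would address that question, and a benzylamino group would show what happens when one carbon stands between the amine nitrogen and the phenyl ring.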